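The source may hold more compounds than are shown below. What is called first, only, known or untested is meant among the compounds shown, and "the series" means these compounds.

Three pyrazoline-type compounds were assessed in a functional assay on Ehrlich cells (Mus musculus) for cytotoxicity, read by trypan blue exclusion, with a stated time of 24 h, tested at 25 uM; on this read-out higher numbers stand for a stronger effect at the one concentration tested and lower numbers for a weaker effect. Compound 1 `COc1ccc(/C=C2\CN(C)CC3C2=NN(c2nc(-c4ccc(Cl)cc4)cs2)C3c2ccc(OC)cc2)cc1` gives 29.2% in this assay. Compound 2 `COc1ccc(/C=C2\CCCC3C2=NN(C2=NC(=O)/C(=C/c4ccc(OC)c(OC)c4)S2)C3c2ccc(OC)cc2)cc1` gives 20.4% in this assay. Compound 3 `CCN1C/C(=C\c2ccc(OC)cc2)C2=NN(C(N)=S)C(c3ccc(OC)cc3)C2C1` gives 31.7% in this assay, the highest of the three numbers. The nearest to compound 3 is compound 1, whose number is lower by an amount that lies within the scatter of repeated measurements, so the two cannot be told apart; the furthest is compound 2, whose number is lower by an amount beyond the scatter.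

Compound 4 `CCN1C/C(=C\c2ccc(OC)cc2)C2=NN(c3nc(-c4ccc(Cl)cc4)cs3)C(c3ccc(OC)cc3)C2C1` has not yet been measured. It differs from compound 3 by one change: a group of 12 heavy atoms (9 carbon, 1 nitrogen, 1 sulfur, 1 chlorine; one five-membered aromatic ring with 2 hetero atoms, one six-membered aromatic ring of carbon only) in place of a group of 3 heavy atoms (1 carbon, 1 nitrogen, 1 sulfur; no ring), on an amine nitrogen in a ring. Going by the values given here, no pair of measured compounds differing in a single place is available to gauge the effect of such a change, so the expectation rests on the narrow spread of the three measured numbers and on compound 3 standing at 31.7%. The step in this assay from compound 3 to compound 4 is expected to be small, in no particular direction, and not beyond the scatter. The step of a number 2.7 percentage points lower from compound 3 to compound 4 (within the scatter) is the estimate that follows. Compound 4 is thus expected to give about 29% in this assay, within an estimated range from 15% to 43%.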

Compound 4, a percentage reported as activity, at one concentration (the size of the read-out at that concentration, not a potency) in the Ehrlich assay: 98.3%
Compound 4: the middle estimate sits 69.3 percentage points below what was measured, outside the stated range (above it).
By their numbers in the Ehrlich assay, from the lowest: compounds 2, 1 and 3 (each within the scatter of the next, the first and the last beyond it); then compound 4.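

Going by these compounds alone, in the Ehrlich assay, putting 4-(4-chlorophenyl)-1,3-thiazol-2-yl on the amine nitrogen in a ring gives a number 66.6 percentage points higher from compound 3 to compound 4 (beyond the scatter), which shows that the read-out can respond strongly to a change at this position, something the narrow spread of the earlier compounds did not reveal. The thiazolyl group is not enough on its own, however: compound 1 carries the same group, and a single methyl on the saturated chain carbon bound to the amine nitrogen in the other ring gives a number 69.1 percentage points higher from compound 1 to compound 4 (beyond the scatter), so the high number appears only when both features are present in compound 4. The effect also does not carry over to the second read-out: in a physicochemical assay for inhibition, read by colorimetric assay, tested at 1 mg/mL (on this read-out lower numbers stand for less inhibition and higher numbers for more inhibition at the one concentration tested (going by the name of the read-out)), compound 3 gives 88.2% and compound 4 gives 82.6%, and the two lie within the scatter of each other.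

Nothing given here explains this sharp dependence on two small features. The compounds shown leave open whether a longer chain such as propyl on that ring amine would hold the high number, and whether bromine in place of the chlorine on the phenyl ring would do the same.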